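The source may hold more compounds than are shown below. What is called first, only, known or untested is meant among the compounds shown, and "the series" means these compounds.

Compound 1 `COc1ccc(-c2cc3ccccc3nc2/C=C/C(=O)c2ccc(O)cc2)cc1` gives 6930 nM in a functional assay on NCI-H460 cells (Homo sapiens) for antiproliferative activity, read by XTT assay, with a stated time of 72 h; a higher number here means a weaker inhibitor, a lower number a stronger inhibitor.
Compound 2 `COc1ccc(-c2cc3ccccc3nc2/C=C/C(=O)c2c(OC)cccc2OC)cc1` gives 6630 nM in this assay.
Compound 3 `COc1ccc(-c2cc3ccccc3nc2/C=C/C(=O)c2ccco2)cc1` gives 6430 nM in this assay.

Compound 2 stands second highest of these three numbers; its nearest neighbour is compound 3 and its furthest is compound 1, and both gaps lie within the scatter. Compound 4 `COc1ccc(-c2cc3ccccc3nc2/C=C/C(=O)c2cccs2)cc1` differs from compound 2 by thiophen-2-yl in place of 2,6-dimethoxyphenyl on a carbonyl carbon. The closest parallel is the step in which a six-membered aromatic ring of carbon only gave way to a five-membered aromatic ring with one hetero atom at the same carbonyl carbon, which showed a 1.0-fold lower number from compound 2 to compound 3 (0.01 log units; within the scatter); the other two steps, a 1.0-fold lower number from compound 1 to compound 2 (0.02 log units; within the scatter) and a 1.1-fold lower number from compound 1 to compound 3 (0.03 log units; within the scatter), also stayed within the scatter. Compound 4 is therefore expected to show no shift beyond the scatter in this assay, a 1.0-fold lower number from compound 2 to compound 4 (0.00 log units; within the scatter). The estimate for compound 4 is 6600 nM, ranging from 3300 nM to 13000 nM.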

Compound 4, half-maximal inhibitory concentration: 5440 nM
Compound 4: the middle estimate sits 1.2-fold (0.08 log units) above what was measured, within the range that was stated.
By their numbers in this assay, from the lowest: compounds 4, 3, 2 and 1 (each within the scatter of the next).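

With thiophen-2-yl on the carbonyl carbon, this assay still shows no shift beyond the scatter, with a 1.2-fold lower number from compound 2 to compound 4 (0.09 log units; within the scatter), a 1.2-fold lower number from compound 3 to compound 4 (0.07 log units; within the scatter) and a 1.3-fold lower number from compound 1 to compound 4 (0.11 log units; within the scatter). A sulfur-bearing five-membered aromatic ring therefore joins the other three aromatic groups, and all four compounds lie within the scatter of one another at this position. Nothing shown explains this flat result. As far as these compounds go, it remains open whether a group without an aromatic ring, such as a plain alkyl chain, would move the number beyond the scatter. The same question stands for an amine or a carboxylic acid attached to the ring.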